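Cyclopropyl for phenyl on the ring nitrogen

The source may hold more compounds than are shown below. What is called first, only, known or untested is meant among the compounds shown, and "the series" means these compounds.

- compound 1 `COc1cccc(N2C(=O)COc3ccc(-c4cnc(OC)c(NS(=O)(=O)c5ccc(F)cc5)c4)cc32)c1`: > 40000 nM (a limit)
- compound 2 `COc1ncc(-c2ccc3c(c2)N(c2ccccc2)C(=O)CO3)cc1NS(=O)(=O)c1ccc(F)cc1`: 8870 nM
- compound 3 `COc1ncc(-c2ccc3c(c2)N(C2CC2)C(=O)CO3)cc1NS(=O)(=O)c1ccc(F)cc1`: not yet measured

Among the compounds with values here, in a functional assay on MCF7 cells (Homo sapiens) for antiproliferative activity, read by MTT assay, with a stated time of 72 h (on this read-out higher numbers stand for weaker inhibition and lower numbers for stronger inhibition), compound 2 gives 8870 nM, the only actual number so far. The reading for compound 1 is a limit, > 40000 nM.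

The next change is cyclopropyl in place of phenyl on an amide-type nitrogen in a ring. Within the data shown here, the one measured step is an at least 4.5-fold lower number from compound 1 to compound 2 (0.65 log units; beyond the scatter), for hydrogen in place of methoxy on an aromatic carbon. It concerns the phenyl that now leaves, but it is a different change and a single step, so it gives only weak guidance. A modest move toward lower numbers in this assay is expected, with no change beyond the scatter also quite possible. The expected step is a 1.8-fold lower number from compound 2 to compound 3 (0.25 log units; within the scatter). For compound 3 the estimate is 5000 nM, with an expected range of 1200 nM to 25000 nM.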

Compound 3, half-maximal inhibitory concentration: 35200 nM
Beside the measured number, compound 3's estimate is 7.0-fold (0.85 log units) below it; measured number above the stated range.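

In this assay, the amide-type nitrogen in a ring is sensitive to what it carries: cyclopropyl in place of phenyl gives a 4.0-fold higher number from compound 2 to compound 3 (0.60 log units; beyond the scatter). This is the first step at this position that replaces the phenyl itself, and compound 2, with plain phenyl, keeps the lowest number among the compounds shown, since both departures from it, 3-methoxyphenyl and cyclopropyl, give higher readings. Cyclopropyl in place of 3-methoxyphenyl gives an at least 1.1-fold lower number from compound 1 to compound 3 (0.05 log units; that floor lies within the scatter), but this step is only a floor, as the reading for compound 1 is only a limit: the limit of > 40000 nM in this assay, at which 1 of the 3 values shown sits.

The compounds shown do not settle whether an aromatic ring on this nitrogen is what matters, as only two kinds of carbon ring are compared. From the compounds shown here alone, how a benzyl group, a pyridyl ring or a plain hydrogen on this nitrogen would read remains open.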